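This account rests on a few compounds, and the source may have more. Where it says the series, first, only, none or still open, it means among the compounds named here.

Working notes on the series. Compound 1 (`COc1cc(OC)c(OC)cc1/C=C/COC(=O)/C=C/c1ccc(OC)c(OC)c1`) and compound 2 (`COc1cc(OC)c(OC)cc1/C=C/COC(=O)/C=C/c1cc(OC)c(OC)c(OC)c1OC`) are the only esters measured so far. In a functional assay on the whole organism (strain Kunming) with Mus musculus as the target, with a stated time of 0.5 h (a higher number here means that more compound is needed for the effect, a lower number that less compound is needed), compound 1 gives > 300 mg/kg, which is a limit of the assay and not a number. In this assay, compound 2 gives > 200 mg/kg, which is also a limit and not a number. Among the compounds with values here, compound 2 therefore has no numeric value, and the pair gives no measured step to work from.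

The next compound is compound 3 (`COc1cc(OC)c(OC)cc1/C=C/COC(=O)/C=C/c1ccc(OC)c(OC)c1OC`), which differs from compound 2 by hydrogen in place of methoxy on an aromatic carbon. In words, hydrogen stands in place of methoxy on an aromatic carbon, and the rest of the structure is unchanged.

The expectation rests only on the two limits, as neither measured compound has yet given a number. In this assay, the expected step is a step that the limit leaves unreadable from compound 2 to compound 3, with no change beyond the scatter expected and no direction favoured. Another result reported only as a limit would fit this expectation. For compound 3 the estimated dose is 250 mg/kg, with an expected range of 100 mg/kg to 500 mg/kg.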

Compound 3, dose for half-maximal effect: > 300 mg/kg
Compound 3 was reported as a limit; the forecaster's own chance of this, stated with the estimate: 65%; middle value at least 1.2-fold (0.07 log units) away from the limit.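

In this assay compound 3 gives > 300 mg/kg, which is a limit and not a number. Within the data shown here, compound 1 and compound 2 also stand only as limits, so no step to compound 3 can be read from either. The compounds shown leave open what dose any of these esters needs in this assay, and whether hydrogen in place of methoxy on an aromatic carbon changes it.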